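The compounds below may be only part of what the source reports. "The series", "measured", "known", "first", "only" and "open" are said of these compounds alone.

Measured so far in a functional assay on PC-12 cells (Rattus norvegicus) for cytotoxicity, read by MTT assay, with a stated time of 24 h, tested at 5 uM; a lower number here means a weaker effect, a higher number a stronger effect of the compound at the concentration tested:

Compound 1 `CC1=CC(=O)O[C@@]2(CC(=O)C(C)C)[C@@H](C)CC[C@@H]12` gives 83.5%
Compound 2 `CC1(C)CCC[C@]2(C)[C@@H]1CC[C@](O)(CO)[C@H]2C/C=C1\CCOC1=O` gives 72.2%
Compound 3 `CC1=C2CC(=O)[C@@H](C)CC/C=C(\C)C[C@H]2OC1=O` gives 77.4%

Of the compounds shown here, three have been tested, and each is read as the percentage effect at a single concentration, not as a potency. Compound 1 gives the highest of the three numbers. Compound 3 comes nearest to it, and its number lies within the usual scatter of compound 1, so the two cannot be told apart. Compound 2 lies furthest away, and its gap to compound 1 is beyond the scatter. No two of these three differ in only one place, so none of the gaps between them can be tied to a single structural change.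

Compound 4 `C=C(C)C(=O)C[C@@]12OC(=O)C=C(C)[C@@H]1CC[C@@H]2C` has not yet been measured. It differs from compound 1 in one place: 1-methylethenyl in place of isopropyl on a carbonyl carbon. The group that leaves and the group that enters have the same count of heavy atoms, all carbon; the entering group brings one double bond outside aromatic rings, and neither group carries a hydrogen-bond donor or acceptor.

Among the measured compounds shown here, with no measured step of this kind to lean on, compound 1 with 83.5% is the only anchor. The step of a number 1.5 percentage points higher from compound 1 to compound 4 (within the scatter) is expected to be small, not beyond the scatter, in either direction. Compound 4 is therefore expected to give about 85%, within a range from 70% to 96%.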

Compound 4, a percentage reported as activity, at one concentration (the size of the read-out at that concentration, not a potency): 72.4%
Beside the measured number, compound 4's estimate is 12.6 percentage points above it; low and high end bracket the measured number.
By their numbers in this assay, from the lowest: compounds 2, 4, 3 and 1 (each within the scatter of the next, the first and the last beyond it).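

The step of a number 11.1 percentage points lower from compound 1 to compound 4 (beyond the scatter) in this assay is the first difference among these compounds that can be tied to one place, and it shows that the number responds to what sits on this carbonyl carbon. The two groups have the same count of heavy atoms, all carbon, and neither carries a hydrogen-bond donor or acceptor, so the one double bond that 1-methylethenyl brings is the only difference counted here, even though this single pair cannot establish that it matters in general. Nothing available here explains why this change goes with a weaker effect at the concentration tested.

The compounds shown leave open whether the lower number belongs to the double bond itself or to 1-methylethenyl as a whole, which an ethyl group, a cyclopropyl group or a longer chain on the same carbonyl carbon could help to separate. They also leave open how an amine or a carboxylic acid at this place would behave, and whether the same change would give a similar step on a different core.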